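A few compounds are considered here, and "the series" means these few. Any claim that something is new, unique, unknown or untested is made for them only; others in the source may bear on it.

Of the compounds shown here, three have been measured in a functional assay on SK-MEL-2 cells (Homo sapiens) for cytotoxicity, read by sulforhodamine B assay, with a stated time of 48 h, tested at 1 uM; on this read-out higher numbers stand for a weaker effect at the one concentration tested and lower numbers for a stronger effect. Compound 1 `COc1cc(-c2cc(/C=C/C(=O)c3ccc(N)cc3)[nH]n2)cc(OC)c1OC` gives 104%. Compound 2 `COc1ccc(C(=O)/C=C/c2cc(-c3cc(OC)c(OC)c(OC)c3)n[nH]2)cc1OC` gives 98%. Compound 3 `COc1ccc(C(=O)/C=C/c2cc(-c3cc(OC)c(OC)c(OC)c3)n[nH]2)cc1` gives 97%. Compound 2 stands second highest of these three numbers; its nearest neighbour is compound 3, since a number 1 percentage points lower from compound 2 to compound 3 (within the scatter), and its furthest is compound 1, since a number 6 percentage points lower from compound 1 to compound 2 (within the scatter).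

Compound 4 `COc1cc(C(=O)/C=C/c2cc(-c3cc(OC)c(OC)c(OC)c3)n[nH]2)cc(OC)c1OC` has not yet been measured. It differs from compound 2 by methoxy in place of hydrogen on an aromatic carbon. The closest guide is the measured step running the other way, where a number 1 percentage points lower from compound 2 to compound 3 (within the scatter). The remaining steps, which also touch that same six-membered aromatic ring, were a number 6 percentage points lower from compound 1 to compound 2 (within the scatter) and a number 7 percentage points lower from compound 1 to compound 3 (within the scatter). None of these changes has moved the read-out beyond the scatter, so no step beyond the scatter is expected here either: in expectation no change at the digits printed from compound 2 to compound 4 (within the scatter). The estimate for compound 4 in this assay is 98%, with a range from 88% to 108%.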

Compound 4, a percentage reported as activity, at one concentration (the size of the read-out at that concentration, not a potency): 97%
Compound 4: middle estimate off by 1 percentage points, on the high side; the measured number falls inside the stated range.
By their numbers in this assay, from the lowest: compounds 3, 4, 2 and 1 (each within the scatter of the next).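

Placing a methoxy group on this aromatic carbon, ortho to a methoxy group, meta to a large group and meta to a methoxy group, gives a number 1 percentage points lower from compound 2 to compound 4 (within the scatter) in this assay on the same ring that carries the carbonyl. Read with the earlier removal of a methoxy group, which gave a number 1 percentage points lower from compound 2 to compound 3 (within the scatter) on that ring, the new step shows that neither adding nor removing a methoxy group there has moved the number beyond the scatter. No measurement here gives a reason for this result.

Going by these compounds, whether a group of another kind at this position, such as a hydroxyl, a chlorine atom or a carboxylic acid, would leave the number where it is stays open. The compounds shown also leave open whether any change on this ring can produce a step beyond the scatter in this cell assay.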